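The compounds below may be only part of what the source reports. "The series", "measured", "known", "first", "only" and "open" are said of these compounds alone.

In a functional assay on A549 cells (Homo sapiens) for cytotoxicity, read by WST assay, with a stated time of 24 h (a lower number here means a stronger inhibitor, a higher number a weaker inhibitor), compound 1 `COc1ccc2c(/C=C(\C#N)C(=O)c3c[nH]c4cc(F)ccc34)c[nH]c2c1` gives 10300 nM, and compound 3 `N#C/C(=C\c1cn(Cc2ccc(Cl)cc2)c2ccc(Br)cc12)C(=O)c1c[nH]c2ccccc12` gives 14000 nM, so these two values lie within the scatter of each other. Compound 2 `N#C/C(=C\c1c[nH]c2cc(F)ccc12)C(=O)c1c[nH]c2cc(F)ccc12` gives > 50000 nM, which is a limit of the assay and not a number. Compound 4 `COc1ccc2c(/C=C(\C#N)C(=O)c3c[nH]c4ccccc34)c[nH]c2c1` keeps the core of compound 1 and differs from it by hydrogen in place of fluoro on an aromatic carbon. For the measured compounds named here, the one measured step, an at least 4.8-fold higher number from compound 1 to compound 2 (0.68 log units; beyond the scatter), replaces methoxy with fluoro, so it touches a different group and bears on this change only loosely. In this assay, no change beyond the scatter is therefore expected, and the estimated step is a 1.2-fold higher number from compound 1 to compound 4 (0.07 log units; within the scatter). For compound 4 the estimated value is 12000 nM, with an expected range from 4500 nM to 35000 nM.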

Compound 4, half-maximal inhibitory concentration: 9600 nM
The estimate for compound 4 lay 1.3-fold (0.10 log units) above the measured number; the range from low to high includes it.
By their numbers in this assay, from the lowest: compounds 4, 1 and 3 (each within the scatter of the next). At a limit, above all of these: compound 2.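

Putting hydrogen in place of fluoro on this aromatic carbon gives, in this assay, a 1.1-fold lower number from compound 1 to compound 4 (0.03 log units; within the scatter), so the two compounds cannot be told apart in this assay. For the compounds shown here, the earlier step changed the methoxy group, whereas this one is the first to test the fluoro position directly, and on the core of compound 1 the fluoro makes no measurable difference. Nothing shown here offers a reason for this result.

Going by these compounds, whether an amine or a carboxylic acid on this same carbon would shift the number remains open. A chlorine or a methyl group there is equally untested among the compounds shown.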